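Moving the carboxyl group and the maximal response

A few compounds are considered here, and "the series" means these few. Any claim that something is new, unique, unknown or untested is made for them only; others in the source may bear on it.

This account concerns a pair of phenol ketones that share a core and are tested in an assay on HEK293 cells for positive allosteric modulation of metabotropic glutamate receptor 3 (Rattus norvegicus), read by thallium flux, with a stated time of 2.5 min; a lower number here means a smaller maximal response, a higher number a larger maximal response. Among the measured compounds shown here, compound 1, with the structure `Cc1c(OCCCCOc2ccccc2C(=O)O)ccc(C(=O)CC(C)C)c1O`, gives 28.1% in this assay, the lower of the two numbers measured so far. Compound 2, with the structure `Cc1c(OCCCCOc2ccccc2C(=O)O)ccc(C(=O)CC2CCCC2)c1O`, gives 32.9% in this assay. For the measured compounds named here, the only measured step is a number 4.8 percentage points higher from compound 1 to compound 2 (within the scatter), which concerns the ketone side of the molecule, not the aryl ether end.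

Compound 3, with the structure `Cc1c(OCCCCOc2cccc(C(=O)O)c2)ccc(C(=O)CC(C)C)c1O`, differs from compound 1 as follows: 3-carboxyphenyl in place of 2-carboxyphenyl on an oxygen on a saturated carbon. Going by the values given here, no measured step touches this part of the molecule, so nothing among the two measured compounds speaks directly to the size or direction of the change. Among the compounds with values here, the single step in hand was within the scatter and lies elsewhere, so the expectation for compound 3 rests on compound 1 alone, with a wide range. Compound 3 is therefore expected to give about 30% in this assay, between 10% and 55%. The expected step of a number 1.9 percentage points higher from compound 1 to compound 3 (within the scatter) is not expected to exceed the scatter.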

Compound 3, largest response reached (reported as percent of maximum), in percent of the reference or control that the assay uses: 69.9%
Estimate against measurement, compound 3: 39.9 percentage points below, and the stated range ends below it.
By their numbers in this assay, from the lowest: compounds 1 and 2 (each within the scatter of the next); then compound 3.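

Moving the carboxyl group at the aryl ether end matters far more in this assay than the one change on the ketone side: putting 3-carboxyphenyl in place of 2-carboxyphenyl, on an oxygen on a saturated carbon, gives a number 41.8 percentage points higher from compound 1 to compound 3 (beyond the scatter), whereas the earlier step, a number 4.8 percentage points higher from compound 1 to compound 2 (within the scatter), stays within the scatter. The two structures hold the same atoms, joined differently, and the leaving and entering groups have the same counts, so this large step comes from a change in where the carboxyl group is attached to the ring and not from a change in what the molecule contains. Nothing available accounts for why this arrangement goes with the larger maximal response.

The compounds shown leave open whether the step carries over to the cyclopentyl ketone of compound 2, since that group has been seen only with 2-carboxyphenyl. They also leave open what a tetrazole or a primary amide in place of the carboxylic acid on the 3-carboxyphenyl group would give, and how a shorter or longer chain in place of the present one would alter the response.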